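A few compounds are considered here, and "the series" means these few. Any claim that something is new, unique, unknown or untested is made for them only; others in the source may bear on it.

Compound 1 `O=C(O)c1ccc2c(c1)no[n+]2[O-]`: "not determined" (no result reported)
Compound 2 `O=C(CCCCOC(=O)c1ccc2c(c1)no[n+]2[O-])NO`: 1210 nM
Compound 3 `O=C(CCCCCOC(=O)c1ccc2c(c1)no[n+]2[O-])NO`: 11600 nM
Compound 4 `O=C(CCCCCCOC(=O)c1ccc2c(c1)no[n+]2[O-])NO`: not yet measured

In a functional assay on HEL cells (Homo sapiens) for inhibition, read by MTT assay, with a stated time of 48 h (a lower number here means a stronger inhibitor, a higher number a weaker inhibitor), compound 2 gives 1210 nM, the lower of the two numbers available, while compound 1 offers no number for comparison. The change under study is 2-(hydroxycarbamoyl)ethyl in place of hydroxycarbamoyl on a saturated chain carbon, four bonds along the chain from an oxygen next to a carbonyl group. Within the data shown here, only one measured step bears on it: a 9.6-fold higher number from compound 2 to compound 3 (0.98 log units; beyond the scatter), a modest step beyond the scatter. There, (hydroxycarbamoyl)methyl replaces hydroxycarbamoyl at the same place, so compound 4, with 2-(hydroxycarbamoyl)ethyl, continues the same chain extension. A single step cannot show whether the rise goes on, levels off or turns back, so the expectation stays broad. A higher number is expected, of roughly the size already seen, and the expected step is an 8.3-fold higher number from compound 2 to compound 4 (0.92 log units; beyond the scatter). The estimate for compound 4 is 10000 nM, with an expected range of 2500 nM to 40000 nM.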

Compound 4, half-maximal inhibitory concentration: 1260 nM
Compound 4: the middle estimate sits 7.9-fold (0.90 log units) above what was measured; the whole stated range lies above it.
By their numbers in this assay, from the lowest: compounds 2 and 4 (each within the scatter of the next); then compound 3.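

Chain extension at this position does not keep raising the number in this assay: 2-(hydroxycarbamoyl)ethyl in place of hydroxycarbamoyl gives a 1.0-fold higher number from compound 2 to compound 4 (0.02 log units; within the scatter), and the other new step reads a 9.2-fold lower number from compound 3 to compound 4 (0.96 log units; beyond the scatter). Compound 3 therefore stands apart from the other two, and compound 4 goes against any steady rise with chain length across these three compounds, so the first step did not mark a general penalty for a longer chain. No measurement in hand explains why compound 3 stands apart.

As far as these compounds go, whether a longer chain than that of compound 4 holds this level or moves away from it remains open. Also open, from the compounds shown here alone, is how a carboxylic acid or an amine at the chain end would compare with hydroxycarbamoyl.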